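A few compounds are considered here, and "the series" means these few. Any claim that something is new, unique, unknown or untested is made for them only; others in the source may bear on it.

Measured so far in a functional assay on CHO cells for antagonist activity at C-C chemokine receptor type 4 (Homo sapiens), read by GTPgammaS binding; a lower number here means a stronger inhibitor, a higher number a weaker inhibitor:
compound 1, `COc1cccc2c1c(NS(=O)(=O)c1ccc(Cl)s1)nn2Cc1cccc(CNC(=O)C2COC2)c1`, 20 nM
compound 2, `COc1cccc2c1c(NS(=O)(=O)c1cccc(Cl)c1)nn2Cc1cccc(CNC(=O)C(C)(C)O)c1`, 50.1 nM

Compound 2 has the higher of the two numbers; its nearest neighbour is compound 1, whose number is lower by an amount beyond the usual scatter of repeated measurements. The two compounds differ in more than one place, so nothing can be said about which change carries that gap. Compound 3, `COc1cccc2c1c(NS(=O)(=O)c1ccc(C)c(F)c1)nn2Cc1cccc(CNC(=O)C(C)(C)O)c1`, has not yet been measured. It differs from compound 2 in a single place: 3-fluoro-4-methylphenyl in place of 3-chlorophenyl on a sulfonyl sulfur. For the measured compounds named here, no pair of measured compounds shows this kind of exchange, so there is no measured step to lean on. Since both groups are six-membered aromatic rings of carbon only, with no hydrogen-bond donors or acceptors, only a small step is expected in this assay, in either direction or none beyond the scatter. Compound 3 is therefore expected to come out at about 60 nM, between 20 nM and 180 nM. The step this estimate implies, a 1.2-fold higher number from compound 2 to compound 3 (0.08 log units; within the scatter), is expected to be small.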

Compound 3, half-maximal inhibitory concentration in the C-C chemokine receptor type 4 assay: 15.9 nM
Beside the measured number, compound 3's estimate is 3.8-fold (0.58 log units) above it; the measured number lies below the stated range.
By their numbers in the C-C chemokine receptor type 4 assay, from the lowest: compounds 3 and 1 (each within the scatter of the next); then compound 2.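

For the compounds shown here, on the sulfonyl sulfur, the choice of aromatic group matters: in the C-C chemokine receptor type 4 assay, compound 2 gives 50.1 nM and compound 3 gives 15.9 nM, and 3-fluoro-4-methylphenyl in place of 3-chlorophenyl gives a 3.2-fold lower number from compound 2 to compound 3 (0.50 log units; beyond the scatter), the first comparison here that changes one place only. This step appears even though both groups count as one six-membered aromatic ring of carbon only, with no hydrogen-bond donors or acceptors, while in a physicochemical assay for acid dissociation, compound 2 gives 7.06 and compound 3 gives 7.26, and the same exchange gives a number 0.20 log units higher from compound 2 to compound 3 (within the scatter), so the two compounds do not separate on that read-out. Nothing shown gives a reason for the step in inhibition.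

Still open, going by these compounds, is whether the fluorine, the methyl or the two together carry the step. Also open, on these data alone, is how this position would respond to a pyridine ring, or to a phenyl ring bearing an amine or a carboxylic acid.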